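Trading Trifluoromethyl for Phenyl on a Shared Core

The source may hold more compounds than are shown below. What is called first, only, known or untested is meant among the compounds shown, and "the series" means these compounds.

In a functional assay on SK-MEL-2 cells (Homo sapiens) for inhibition, read by sulforhodamine B assay, with a stated time of 48 h, tested at 10 uM (on this read-out lower numbers stand for less inhibition of growth and higher numbers for more inhibition of growth at the one concentration tested), compound 1 (`C/C(=N/O)c1ccc(NC(=O)Cn2nc(C(F)(F)F)nc2N)cc1`) gives 13.1%. Compound 2 (`COc1cc(-c2nc(N)n(CC(=O)Nc3ccc(/C(C)=N\O)cc3)n2)cc(OC)c1OC`) gives 8%, so these two values lie within the usual scatter of each other. Compound 3 (`C/C(=N/O)c1ccc(NC(=O)Cn2nc(-c3ccccc3)nc2N)cc1`) has phenyl in place of trifluoromethyl on an aromatic carbon. Compound 2 also bears a six-membered aromatic ring of carbon only at that spot and gives 8%, so no change beyond the scatter is expected in this assay. The estimated a number 2.1 percentage points lower from compound 1 to compound 3 (within the scatter) is small. Compound 3 is expected to give 11%, within an estimated range of 3% to 22%.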

Compound 3, percent growth inhibition at one concentration: 5.32%
Beside the measured number, compound 3's estimate is 5.7 percentage points above it, and the stated range covers the measured number.
By their numbers in this assay, from the lowest: compounds 3, 2 and 1 (each within the scatter of the next).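

In this assay the change of trifluoromethyl to phenyl gives a number 7.8 percentage points lower from compound 1 to compound 3 (within the scatter), so on the shared core this aromatic carbon accepts the larger ring with no change beyond the usual scatter. Among the compounds shown here, this is the first comparison at this position in which only one place differs, something compound 1 and compound 2 could not provide. No measured evidence is available to explain this result. The compounds shown leave open whether any other group on this carbon, such as an amine or a carboxylic acid, would shift growth inhibition beyond the scatter.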